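Butyl versus cyclobutyl on the amide carbonyl of an aminophenyl thiadiazoline series

The source may report more compounds than this note shows. Statements on the series, on what has been measured and on what is new or still open speak of the compounds shown alone.

The series rests on a shared core carrying an aminophenyl group and an acylated ring nitrogen. Compound 1 `CCCCC(=O)N1N=C(c2cc(Cl)ccc2N)SC1(C)C` bears a chloro on the aromatic ring and a butylcarbonyl; compound 2 `CC1(C)SC(c2cc(Cl)ccc2N)=NN1C(=O)C1CCC1` keeps the chloro and carries a cyclobutylcarbonyl; compound 3 `CCCCC(=O)N1N=C(c2ccccc2N)SC1(C)C` has the butylcarbonyl without the chloro; compound 4 `CC1(C)SC(c2ccccc2N)=NN1C(=O)C1CCC1` pairs the cyclobutylcarbonyl with the unsubstituted aromatic ring and has not been measured.

In an assay on isolated protein for inhibition of Nitric oxide synthase, inducible (Homo sapiens), read by scintillation counting, with a stated time of 30 min, tested at 50 uM (on this read-out lower numbers stand for less inhibition and higher numbers for more inhibition at the one concentration tested (going by the name of the read-out)), compound 1 gives 12.6%. In this assay compound 2 gives -4.65%, and compound 3 gives 39.1%. The change cyclobutyl in place of butyl on a carbonyl carbon gave a number 17.3 percentage points lower from compound 1 to compound 2 (beyond the scatter). The change hydrogen in place of chloro on an aromatic carbon gave a number 26.5 percentage points higher from compound 1 to compound 3 (beyond the scatter), which leaves compound 3 as the highest of the three measured numbers, both of its steps to the others lying beyond the scatter.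

Compound 4 differs from compound 3 by cyclobutyl in place of butyl on a carbonyl carbon, the same change as that from compound 1 to compound 2, at a place described in identical terms. The two cores differ by hydrogen in place of chloro on an aromatic carbon. With one earlier instance of this change only, the expected step is taken from it: a number 17.1 percentage points lower from compound 3 to compound 4 (beyond the scatter) is estimated beside a number 17.3 percentage points lower from compound 1 to compound 2 (beyond the scatter), resting on compound 1 at 12.6% falling to compound 2 at -4.65%. Compound 4 is thus expected to give about 22%, with a range estimated from 5% to 38% given that a single precedent and a wide scatter underlie it.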

Compound 4, a percentage reported as inhibition, at one concentration (the size of the read-out at that concentration, not a potency): 46.9%
Compound 4: the middle estimate sits 24.9 percentage points below what was measured, outside the stated range (above it).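

In this assay, cyclobutyl in place of butyl on a carbonyl carbon gives a number 7.8 percentage points higher from compound 3 to compound 4 (within the scatter) on the core without the chloro, so the step seen on the chloro-bearing core does not carry over: the same change on two cores in this assay, a number 17.3 percentage points lower (beyond the scatter) from compound 1 to compound 2 and a number 7.8 percentage points higher (within the scatter) from compound 3 to compound 4, 25.1 percentage points apart, beyond the scatter of two such steps. Hydrogen in place of chloro on an aromatic carbon gives a number 51.6 percentage points higher from compound 2 to compound 4 (beyond the scatter) with the cyclobutylcarbonyl, which is not the step seen with the butylcarbonyl: the same change on two cores in this assay, a number 26.5 percentage points higher (beyond the scatter) from compound 1 to compound 3 and a number 51.6 percentage points higher (beyond the scatter) from compound 2 to compound 4, 25.1 percentage points apart, beyond the scatter of two such steps. In these four compounds the two changes therefore do not act independently, and a step read on one core is a poor guide to the same step on the other, but the numbers do not show the reason, nor whether this holds outside this set, each compound being read at a single concentration.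

The compounds shown leave open how a longer chain, an isopropyl or a cyclopentyl on the carbonyl would behave on either core. They also leave open whether a fluoro or a methoxy in place of the chloro would change the outcome of swapping butyl for cyclobutyl in the way the chloro does.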